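The compounds below may be only part of what the source reports. "The series", "measured", "known", "first", "only" and "open" are said of these compounds alone.

Working notes on the dithiocarbamate series.

Three compounds carry the shared core and differ only in the amine fragment attached to the thiocarbonyl carbon. Compound 1 `Nc1ccccc1NC(=O)c1ccc(CSC(=S)N2CCN(C(c3ccccc3)c3ccccc3)CC2)cc1` carries a benzhydryl piperazine; in a functional assay on MGC-803 cells (Homo sapiens) for antiproliferative activity, read by CCK-8 assay, with a stated time of 72 h, tested at 2 uM (a lower number here means a weaker effect, a higher number a stronger effect of the compound at the concentration tested), compound 1 gives 9.8%. Compound 2 `Nc1ccccc1NC(=O)c1ccc(CSC(=S)N2CCN(c3ccc(Cl)cc3)CC2)cc1` carries a chlorophenyl piperazine; in this assay compound 2 gives 15%. Compound 3 `Nc1ccccc1NC(=O)c1ccc(CSC(=S)N2CCc3ccccc32)cc1` carries the 2,3-dihydro-1H-indol-1-yl group; in this assay compound 3 gives 44%. Compound 3 stands highest of the three numbers: its gap to compound 2 is beyond the scatter, and its gap to compound 1, the furthest, is also beyond the scatter. So far the bicyclic amine stands apart from the two piperazines.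

Compound 4 `Nc1ccccc1NC(=O)c1ccc(CSC(=S)N2CCCc3ccccc32)cc1` has not been measured. It differs from compound 3 in one place: 1,2,3,4-tetrahydroquinolin-1-yl in place of 2,3-dihydro-1H-indol-1-yl on a thiocarbonyl carbon. The fragment keeps the fused aromatic ring and the single nitrogen, and grows by one ring atom in the saturated ring. Within the data shown here, no measured pair in the set shows such a ring expansion, so there is no step to lean on. The expectation is a step from compound 3 to compound 4 of a number 2 percentage points lower from compound 3 to compound 4 (within the scatter), that is, no change beyond the scatter, because compound 3 gives 44% and the change is small. Compound 4 is therefore expected to give about 42%, within a range of 25% to 60%.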

Compound 4, a percentage reported as inhibition, at one concentration (the size of the read-out at that concentration, not a potency): 38.5%
Estimate against measurement, compound 4: 3.5 percentage points above; measured number inside the range.
By their numbers in this assay, from the lowest: compounds 1 and 2 (each within the scatter of the next); then compounds 4 and 3 (each within the scatter of the next).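

In this assay, among these compounds, putting 1,2,3,4-tetrahydroquinolin-1-yl in place of 2,3-dihydro-1H-indol-1-yl on a thiocarbonyl carbon gives the first one-place step: a number 5.5 percentage points lower from compound 3 to compound 4 (within the scatter). At this position, then, a six-membered non-aromatic ring can stand in for the five-membered one, with the six-membered aromatic ring and the single nitrogen kept, and the read-out shows no change beyond the scatter. Nothing at hand bears on why the two fragments read alike.

Open, on these data alone, is whether the fused aromatic ring is needed at all, which a piperidin-1-yl group on the thiocarbonyl carbon would test, and whether a seven-membered saturated ring fused to the same aromatic ring would still read like compound 3 and compound 4. Also open, as far as these compounds go, is how a fluorine or a methoxy group on the aromatic ring of the 1,2,3,4-tetrahydroquinolin-1-yl group would read, and whether compound 3 and compound 4 would stay alike at other concentrations, as the read-out gives size at one concentration and not potency.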